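Swapping the chlorothiophene for methoxyphenyl on the sulfonamide

A few compounds are considered here, and "the series" means these few. Any claim that something is new, unique, unknown or untested is made for them only; others in the source may bear on it.

Measured so far in an assay on cells for inhibition of HSP60/HSP10 (Homo sapiens), with a stated time of 60 min; a lower number here means a stronger inhibitor, a higher number a weaker inhibitor:
Compound 1 `O=S(=O)(Nc1ccc(-c2nc3ccccc3o2)cc1)c1ccc(Cl)s1` gives 31000 nM.
Compound 2 `O=S(=O)(Nc1ccc2oc(-c3ccccc3)nc2c1)c1ccccc1Cl` gives only a limit, > 100000 nM.
Compound 3 `COc1ccc(S(=O)(=O)Nc2ccc3oc(-c4ccccc4)nc3c2)cc1` gives only a limit, > 100000 nM.

Among the measured compounds shown here, compound 1 is thus the one compound with a real number; the other two sit at the limit of > 100000 nM in this assay, at which 2 of the 3 values shown sit. For the same reason the step that the two limits leave unreadable from compound 2 to compound 3 cannot be read. Compound 4 `COc1ccccc1S(=O)(=O)Nc1ccc(-c2nc3ccccc3o2)cc1` is still to be measured; it differs from compound 1 by 2-methoxyphenyl in place of 5-chlorothiophen-2-yl on a sulfonyl sulfur. For the measured compounds named here, no measured step touches this exchange, and there is no ground to expect a step beyond the usual scatter in this assay, only a wide uncertainty. Compound 4 is therefore estimated at 40000 nM (range 8000 nM to 200000 nM), which means an expected step of a 1.3-fold higher number from compound 1 to compound 4 (0.11 log units; within the scatter).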

Compound 4, half-maximal inhibitory concentration: > 100000 nM
Compound 4 gave a limit, no number; the forecaster's own chance of this, stated with the estimate: 35%; at least 2.5-fold (0.39 log units) between middle value and limit.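

Placing 2-methoxyphenyl in place of 5-chlorothiophen-2-yl on the sulfonyl sulfur gives an at least 3.2-fold higher number from compound 1 to compound 4 (0.50 log units; beyond the scatter), the first readable step at this position in this assay. The exchange therefore costs inhibition on the core of compound 1, although the true size of the loss is hidden. Compound 4 gives only a limit and joins the other compounds there: the limit of > 100000 nM in this assay, at which 3 of the 4 values shown sit.

Going by these compounds, it remains open whether the chlorine or the thiophene ring matters more for compound 1. A plain thiophen-2-yl or a 4-chlorophenyl on the sulfonyl sulfur would help separate the two.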